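From Compound 2 to Compound 4: Replacing a Nitrogen Substituent

The source may hold more compounds than are shown below. What is called first, only, known or untested is meant among the compounds shown, and "the series" means these compounds.

Of the compounds shown here, three have so far been measured in an in vitro ADME assay on microsomes (Homo sapiens) for metabolic stability; a higher number here means that the compound lasts longer, a lower number that the compound disappears faster. Compound 1 `CCc1nc(NC(CC)CC)c(OC)nc1-c1ccc(OC(F)F)cc1Cl` gives 2 h, compound 3 `CCC(CC)Nc1nc(C)c(-c2ccc(Cl)cc2Cl)nc1C` gives 0.483 h, and compound 2 `CCc1nc(-c2ccc(Cl)cc2Cl)c(CC)nc1NC(COC)COC` gives 0.15 h. Compound 2 therefore has the lowest number of the three, and its gaps to both of the others lie beyond the usual scatter.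

Compound 4 `CCc1nc(-c2ccc(Cl)cc2Cl)c(CC)nc1NC(C1CC1)C1CC1` has not yet been measured. It keeps the rest of compound 2 and changes one substituent, on a nitrogen on an aromatic ring: dicyclopropylmethyl in place of 2-methoxy-1-(methoxymethyl)ethyl on a nitrogen on an aromatic ring. Dicyclopropylmethyl thus takes the place of 2-methoxy-1-(methoxymethyl)ethyl.

For the measured compounds named here, no measured pair isolates this change, since compound 1 and compound 3 differ from compound 2 in more than one place. The expectation therefore rests on limited evidence. Neither compound 3 at 0.483 h nor compound 1 at 2 h carries 2-methoxy-1-(methoxymethyl)ethyl, and both sit higher than compound 2, so a moderate upward step is expected, near the edge of the scatter. The expected change is a 2.3-fold higher number from compound 2 to compound 4 (0.37 log units; beyond the scatter). For compound 4 the estimated half-life in this assay is 0.35 h, with an expected range of 0.12 h to 1 h.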

Compound 4, half-life: 0.183 h
Compound 4: middle estimate off by 1.9-fold (0.28 log units), on the high side; the measured number falls inside the stated range.
By their numbers in this assay, from the lowest: compounds 2 and 4 (each within the scatter of the next); then compound 3; then compound 1.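

In this assay, putting dicyclopropylmethyl in place of 2-methoxy-1-(methoxymethyl)ethyl on a nitrogen on an aromatic ring gives a 1.2-fold higher number from compound 2 to compound 4 (0.09 log units; within the scatter), and this is the first step shown that changes only one place. An open chain with two oxygens and two hydrogen-bond acceptors and a carbon-only group with two three-membered rings therefore cannot be told apart in this read-out on the shared core, so removing those oxygens and adding those rings does not by itself separate the two compounds here. Nothing shown accounts for why these two substituents read alike.

As far as these compounds go, it remains open whether any group at this position can move the half-life beyond the scatter on this core, for instance a carboxylic acid, a tertiary amine or a longer chain ending in a hydroxyl group. From the compounds shown here alone, it is also open whether the same exchange of dicyclopropylmethyl for 2-methoxy-1-(methoxymethyl)ethyl would read alike on the core of compound 1 or the core of compound 3.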